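The source may hold more compounds than are shown below. What is called first, only, known or untested is meant among the compounds shown, and "the series" means these compounds.

Measured compounds:
Compound 1, `Cc1ccc(-c2nc3ccc(Cl)cc3c(=O)[nH]2)cc1`, in a functional assay on HepG2 cells (Homo sapiens) for antiproliferative activity, read by MTT assay, with a stated time of 48 h; a higher number here means a weaker inhibitor, a lower number a stronger inhibitor: 9.86 ug/mL
Compound 2, `Cc1ccc(-c2nc(N)c3cc(Cl)ccc3n2)cc1`, in this assay: 14.5 ug/mL
Compound 3, `Cc1ccc(-c2nc3ccc(Cl)cc3c(=S)o2)cc1`, in this assay: 11.1 ug/mL

Among these three, the number for compound 2 is the highest, but its gap to compound 3 is within the scatter, and so is its gap to compound 1, so the three compounds cannot be told apart on these values. Among the compounds with values here, no pair of them differs in only one place, so no single step is known here.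

Compound 4, `Cc1ccc(-c2nc(SCc3ccccc3)c3cc(Cl)ccc3n2)cc1`, has not yet been measured. It differs from compound 2 in one place: benzylsulfanyl in place of amino on an aromatic carbon. Because no comparable exchange of an amino for a benzylsulfanyl group has been measured on this core, the size and direction of the step are open. Compound 4 is expected to land close to compound 2, with a step of a 1.6-fold lower number from compound 2 to compound 4 (0.21 log units; within the scatter) that is estimated to stay within or just beyond the scatter. The estimate for compound 4 in this assay is 9 ug/mL, with a range from 4 ug/mL to 20 ug/mL.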

Compound 4, half-maximal inhibitory concentration: 18.4 ug/mL
Compound 4: the middle estimate sits 2.0-fold (0.31 log units) below what was measured, within the range that was stated.
By their numbers in this assay, from the lowest: compounds 1, 3, 2 and 4 (each within the scatter of the next).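

In this assay, exchanging amino for benzylsulfanyl on the aromatic carbon next to the ring nitrogen gives a 1.3-fold higher number from compound 2 to compound 4 (0.10 log units; within the scatter), the first single-place step available for this series. At this position, benzylsulfanyl, with its 8 heavy atoms, six-membered aromatic ring and 0 hydrogen-bond donors, can therefore replace amino, with its 1 heavy atom and 1 hydrogen-bond donor, without a change that can be told from the scatter. Nothing available explains why so large an exchange leaves the read-out within the scatter.

The compounds shown leave open whether the sulfur atom or the benzyl ring matters here, a question that benzylamino, benzyloxy or methylsulfanyl at the same carbon could address. They also leave open whether a carboxylic acid or a tertiary amine on a longer chain at this position would move the number in this assay beyond the scatter.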